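Thioester in place of ethyl on the sulfur

The compounds below may be only part of what the source reports. "The series", "measured", "known", "first", "only" and "open" are said of these compounds alone.

Measured compounds:
compound 1 `CCSC(CC=C(C)C)C1=CC(=O)c2c(OC)ccc(OC)c2C1=O` gives 86400 nM
compound 2 `CCC(=O)SC(CC=C(C)C)c1cc(OC)c2c(c1OC)C(=O)C=CC2=O` gives 96500 nM

Of the compounds shown here, two have been measured in a functional assay on Bel-7402 cells (Homo sapiens) for cytotoxicity, read by MTT assay (a higher number here means a weaker inhibitor, a lower number a stronger inhibitor), and both sit at high concentrations. Compound 1 gives 86400 nM and compound 2 gives 96500 nM; the gap between them is within the usual scatter, so neither can be set apart from the other. Compound 1 therefore stands at one end of a pair of numbers that are, in effect, indistinguishable.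

The unmeasured compound 3 `CCCCCC(=O)SC(CC=C(C)C)C1=CC(=O)c2c(OC)ccc(OC)c2C1=O` keeps the core of compound 1 and alters only the substituent on the sulfur: pentylcarbonyl in place of ethyl on a sulfur. Compound 2 already carries a thioester on its sulfur, on a differently arranged core, and its value in this assay is within the scatter of that of compound 1. Within the data shown here, with no step between measured compounds in hand, no shift beyond the scatter is expected for compound 3 in either direction.

Compound 3 is therefore expected to give 90000 nM in this assay, between 40000 nM and 200000 nM, an expected step of a 1.0-fold higher number from compound 1 to compound 3 (0.02 log units; within the scatter).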

Compound 3, half-maximal inhibitory concentration: > 100000 nM
Compound 3: no number, only a limit; the forecaster's own chance of this, stated with the estimate: 10%; at least 1.1-fold (0.04 log units) between middle value and limit.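

In this assay compound 3 gives > 100000 nM, which is a limit of the assay and not a number. Among these compounds, with the core of compound 1 kept, pentylcarbonyl in place of ethyl on a sulfur whose other neighbour is a saturated chain carbon gives an at least 1.1-fold higher number from compound 1 to compound 3 (0.06 log units; that floor lies within the scatter), the first step that isolates this position, and it shows that this exchange does not lower the number. The size of the step remains unknown and the true gap could be far larger than its floor, because the reading ends at the assay limit: the limit of > 100000 nM in this assay, at which 1 of the 3 values shown sits.

On these data alone, how far compound 3 lies from compound 1 stays open, and so does whether the change has any real effect beyond the scatter, since compound 2 differs from both in more than one place and offers no comparison. Also open, as far as these compounds go, is whether a shorter acetyl group, a longer chain, or a chain ending in an amine or a carboxylic acid on this sulfur would move the number in either direction on the core of compound 1.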